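A few compounds are considered here, and "the series" means these few. Any claim that something is new, unique, unknown or untested is made for them only; others in the source may bear on it.

Compound 1 `CC(C)CNC(=N)NC(=N)Nc1ccc(F)c(F)c1`: 2400 nM
Compound 2 `CC(C)NC(=N)NC(=N)Nc1ccc(F)c(F)c1`: 5200 nM
Compound 3 `CCCCCCCNC(=N)NC(=N)Nc1ccc(F)c(F)c1`: not yet measured

In a functional assay on A549 cells (Homo sapiens) for antiproliferative activity, read by MTT assay, with a stated time of 72 h (a lower number here means a stronger inhibitor, a higher number a weaker inhibitor), compound 2 holds the higher of the two numbers at 5200 nM. The move to compound 3 puts heptyl in place of isopropyl on an amine nitrogen. Among the compounds with values here, one measured step bears on this, the modest 2.2-fold higher number from compound 1 to compound 2 (0.34 log units; beyond the scatter), with isopropyl in place of isobutyl. Heptyl is the longer chain, so a moderate step to a lower number is expected in this assay, on thin evidence from a single pair. The expected change is a 4.0-fold lower number from compound 2 to compound 3 (0.60 log units; beyond the scatter). The estimate for compound 3 is 1300 nM, with an expected range of 400 nM to 3800 nM.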

Compound 3, half-maximal inhibitory concentration: 1500 nM
Compound 3: the middle estimate sits 1.2-fold (0.06 log units) below what was measured; the range from low to high includes it.
By their numbers in this assay, from the lowest: compounds 3 and 1 (each within the scatter of the next); then compound 2.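

In this assay the amine nitrogen tolerates a straight heptyl chain as well as the short branched groups, and heptyl in place of isopropyl gives a 3.5-fold lower number from compound 2 to compound 3 (0.54 log units; beyond the scatter). Against compound 1, the step is a 1.6-fold lower number from compound 1 to compound 3 (0.20 log units; within the scatter), so compound 3 cannot be separated from compound 1 and the added chain length brings no clear gain over isobutyl. Among these three compounds, isopropyl alone stands apart. No available data explain these differences. Open, from the compounds shown here alone, is whether a cyclohexyl ring or a terminal amine on the chain would keep this level of activity.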